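This account rests on a few compounds, and the source may have more. Where it says the series, first, only, none or still open, it means among the compounds named here.

Measured so far:
- compound 1, `Clc1ccncc1C1=CC2CNCC(C1)C2`, in an in vitro assay on SH-SY5Y cells for displacement of a labelled ligand from Neuronal acetylcholine receptor; alpha3/beta4 (Homo sapiens) (a lower number here means a stronger inhibitor, a higher number a weaker inhibitor), gives 128 nM
- compound 2, `FC(F)(F)c1cncc(C2=CC3CNCC(C2)C3)c1`, in this assay gives 79 nM

Among these two numbers compound 2 has the lower one, yet its distance from compound 1 lies within the scatter of the measurement, so the two cannot be told apart. Compound 3, `Clc1cncc(C2=CC3CNCC(C2)C3)c1`, is not yet measured. It arises from compound 2 by chloro in place of trifluoromethyl on an aromatic carbon. Among the compounds with values here, no step between measured compounds matches this change; compound 1 also carries a chloro group and gives 128 nM. A step of no more than the scatter is expected here, so compound 3 is estimated at 100 nM, between 40 nM and 250 nM, meaning a 1.3-fold higher number from compound 2 to compound 3 (0.10 log units; within the scatter).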

Compound 3, inhibition constant: 40 nM
Compound 3: the middle estimate sits 2.5-fold (0.40 log units) above what was measured; the range from low to high includes it.
By their numbers in this assay, from the lowest: compounds 3, 2 and 1 (each within the scatter of the next, the first and the last beyond it).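

Putting chloro in place of trifluoromethyl on this aromatic carbon gives a 2.0-fold lower number from compound 2 to compound 3 (0.30 log units; within the scatter), so in this assay the two groups cannot be told apart at this position. This direct comparison shows that a group of 1 heavy atom and one of 4 heavy atoms give results within the scatter here. Within the data shown here, nothing measured so far speaks to what lies behind this result. On these data alone, what a methyl, a nitrile or an amine would give on this same carbon remains open. So does whether this exchange would give a similar step on another core.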